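Swapping a Nitrogen Substituent for Hydrogen

The source may hold more compounds than are shown below. What is called first, only, known or untested is meant among the compounds shown, and "the series" means these compounds.

Values in a functional assay on HT-29 cells (Homo sapiens) for antiproliferative activity, read by MTT assay, with a stated time of 96 h; on this read-out higher numbers stand for weaker inhibition and lower numbers for stronger inhibition:
- Compound 1 `S=C(N/N=C1\CC2(CCCCC2)Oc2c1ccc1ccccc21)NC1CCCCC1`: 7440 nM
- Compound 2 `Cc1ccc(NC(=O)N/N=C2\CC3(CCCCC3)Oc3c2ccc2ccccc32)cc1`: 7090 nM
- Compound 3 `N/N=C1\CC2(CCCCC2)Oc2c1ccc1ccccc21`: not yet measured

The two measured compounds stand level, since compound 2 at 7090 nM lies within the scatter of compound 1 at 7440 nM. The next structure keeps the shared core and changes one place: hydrogen in place of (4-methylphenyl)carbamoyl on an amine nitrogen. In words, hydrogen stands in place of (4-methylphenyl)carbamoyl on an amine nitrogen.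

For the measured compounds named here, only one measured step bears on this change. That step, a 1.0-fold lower number from compound 1 to compound 2 (0.02 log units; within the scatter), also falls on an amine nitrogen and lies within the scatter. It exchanges one large group for another, however, and neither measured compound carries hydrogen at this place. The data therefore contain no direct test of removing the group. With nothing pointing in either direction, no shift beyond the scatter is expected in this assay, though with wide uncertainty. The expected change is a 1.0-fold lower number from compound 2 to compound 3 (0.01 log units; within the scatter). Compound 3 is estimated at 7000 nM, with an expected range from 2500 nM to 20000 nM.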

Compound 3, half-maximal inhibitory concentration: 9970 nM
Estimate against measurement, compound 3: 1.4-fold (0.15 log units) below, and the stated range covers the measured number.
By their numbers in this assay, from the lowest: compounds 2, 1 and 3 (each within the scatter of the next).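

In this assay, the hydrogen form gives the first direct test of leaving the amine nitrogen whose other neighbour is double-bonded nitrogen without a large group: the removal of (4-methylphenyl)carbamoyl amounts to a 1.4-fold higher number from compound 2 to compound 3 (0.15 log units; within the scatter) and the removal of the group carried by compound 1 amounts to a 1.3-fold higher number from compound 1 to compound 3 (0.13 log units; within the scatter), and both steps lie within the scatter. The earlier compounds had shown only that one large group could stand in for another at this place, whereas these steps show that, among these three compounds, neither large group is needed for a number at this level in this read-out. No supporting data are available to explain why the three compounds stand level.

From the compounds shown here alone, whether a different group on this nitrogen, such as a small acetyl, a methyl or a chain ending in a carboxylic acid, would move the number beyond the scatter remains open. Also open, going by these compounds, is how the individual features of the two large groups would act alone, since the step between compound 1 and compound 2 changes several of them at once.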